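Trimming the amide side chain of a diphenylmethylthio acetamide

The source may hold more compounds than are shown below. What is called first, only, known or untested is meant among the compounds shown, and "the series" means these compounds.

Measured so far:
Compound 1 `NC(=O)C[S+]([O-])C(c1cccc(F)c1)c1cccc(F)c1` — 5930 nM
Compound 2 `O=C(CSC(c1ccccc1)c1ccccc1)NCCCc1ccccc1` — 2020 nM

Both numbers come from an assay on brain (strain Sprague-Dawley) for displacement of a labelled ligand from sodium-dependent dopamine transporter (Rattus norvegicus), read by scintillation counting, with a stated time of 120 min; a lower number here means a stronger inhibitor, a higher number a weaker inhibitor. Compound 2 gives the lower of the two values, and the distance from it to compound 1 lies beyond the usual scatter of repeated runs, so on this pair compound 2 is the stronger inhibitor. The two compounds differ in several places at once, so nothing about any single change can be read from that gap.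

Compound 3 `CNC(=O)CSC(c1ccccc1)c1ccccc1` has not yet been measured in this assay. It differs from compound 2 in one place: hydrogen in place of phenethyl on a saturated chain carbon bound to an amide-type nitrogen. Cut one bond further out, the same change reads as 3-phenylpropyl to methyl on the amide nitrogen.

Going by the values given here, with no step of this kind among the measured compounds, the account rests on expectation alone. The change is expected to move the number upward, that is, toward weaker inhibition, by a step of moderate size that should exceed the scatter: the step from compound 2 to compound 3 is estimated as a 2.7-fold higher number from compound 2 to compound 3 (0.44 log units; beyond the scatter). Compound 3 is therefore expected to give about 5500 nM, within a range of 2000 nM to 15000 nM.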

Compound 3, inhibition constant: 19300 nM
The estimate for compound 3 lay 3.5-fold (0.55 log units) below the measured number, outside the stated range (above it).
By their numbers in this assay, from the lowest: compound 2; then compound 1; then compound 3.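

Going by these compounds alone, the single change from compound 2 to compound 3 gives the first readable step. In this assay, replacing the 3-phenylpropyl on the amide nitrogen with methyl produces a 9.6-fold higher number from compound 2 to compound 3 (0.98 log units; beyond the scatter) and so moves the number toward weaker inhibition. The amide nitrogen is therefore a position where the substituent matters on the unoxidised, unfluorinated core shared by these two compounds, and the larger group, which holds one six-membered aromatic ring of carbon only, belongs to the stronger inhibitor of the pair. This one step cannot show whether the loss follows from removing the carbon chain or the aromatic ring, and it cannot show how the number changes at intermediate lengths, so a benzyl group, a plain ethyl or butyl chain, or a chain ending in an amine or a carboxylic acid would each remain an open case at this position. Nothing available here accounts for the size of the step or tells why the longer group goes with the lower number.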